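Swapping the aryl on the triazole nitrogen: compound 3 to compound 4

A few compounds are considered here, and "the series" means these few. Any claim that something is new, unique, unknown or untested is made for them only; others in the source may bear on it.

Compound 3 `N#CC1=C(N)Oc2c(N)cc3nc4ccccc4nc3c2C12C(=O)N(Cc1cnnn1-c1ccc([N+](=O)[O-])cc1)c1ccccc12` carries a 4-nitrophenyl on an aromatic nitrogen of a five-membered aromatic ring with 3 nitrogen, attached to a shared core. In a functional assay on A549 cells (Homo sapiens) for antiproliferative activity, read by MTT assay, with a stated time of 48 h (a higher number here means a weaker inhibitor, a lower number a stronger inhibitor), compound 3 gives > 50000 nM, which is a limit of the assay rather than a number. Compound 2 `CC(=O)Nc1ccc(-n2nncc2CN2C(=O)C3(C(C#N)=C(N)Oc4c(N)cc5nc6ccccc6nc5c43)c3ccccc32)cc1`, bearing a 4-acetamidophenyl, also gives a limit in this assay, > 50000 nM. Compound 1 `N#CC1=C(N)Oc2c(N)cc3nc4ccccc4nc3c2C12C(=O)N(Cc1cnnn1-c1ccccc1Cl)c1ccccc12`, bearing a 2-chlorophenyl, gives a measured 29800 nM. The step of an at least 1.6-fold higher number from compound 1 to compound 2 (0.22 log units; that floor lies within the scatter) and the step of an at least 1.6-fold higher number from compound 1 to compound 3 (0.22 log units; that floor lies within the scatter) are both floors that lie within the scatter, and the step that the two limits leave unreadable from compound 2 to compound 3 cannot be read at all, since two of the three values sit at the limit of > 50000 nM in this assay, at which 2 of the 3 values shown sit.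

Compound 4 `Cc1ccc(-n2nncc2CN2C(=O)C3(C(C#N)=C(N)Oc4c(N)cc5nc6ccccc6nc5c43)c3ccccc32)cc1C` differs from compound 3 by 3,4-dimethylphenyl in place of 4-nitrophenyl on an aromatic nitrogen. For the measured compounds named here, no measured step covers a methyl-bearing aryl, and the steps that do exist are small or unreadable. The step of an at least 1.2-fold lower number from compound 3 to compound 4 (0.09 log units; that floor lies within the scatter) is therefore expected to be modest. Compound 4 is estimated at 40000 nM, with a range from 15000 nM to 100000 nM.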

Compound 4, half-maximal inhibitory concentration: > 50000 nM
Compound 4: a limit, no number; the forecaster's own chance of this, stated with the estimate: 50%; at least 1.2-fold (0.09 log units) between middle value and limit.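

Compound 4 puts an all-carbon aryl on this aromatic nitrogen, and in this assay it also ends at a limit of the assay rather than a number. The 4-nitrophenyl, with 2 hydrogen-bond acceptors, and the 3,4-dimethylphenyl, with none, therefore both end at this limit, and among the four aryl groups shown only the 2-chlorophenyl of compound 1 gives a measured value. The change gives an at least 1.6-fold higher number from compound 1 to compound 4 (0.22 log units; that floor lies within the scatter), while the steps among compound 2, compound 3 and compound 4 cannot be read, so no order can be set among these three: the limit of > 50000 nM in this assay, at which 3 of the 4 values shown sit.

Going by these compounds, it remains open whether compound 1 truly differs from the other three. Also open, on these data alone, is how an aryl carrying an amine or a carboxylic acid would fare at this position.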